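This account rests on a few compounds, and the source may have more. Where it says the series, first, only, none or still open, it means among the compounds named here.

Working notes on the series. Three compounds carry results in a functional assay for activation of Alpha-1A adrenergic receptor (Homo sapiens), read by calcium flux; on this read-out lower numbers stand for an effect already at smaller amounts and higher numbers for an effect only at larger amounts of compound. Compound 1 `CCN(CC)C(=O)c1ccccc1OCC1=NCCN1` gives in this assay only a limit of the assay, < 5020 nM. Compound 3 `Cc1cccnc1-c1ccccc1OCC1=NCCN1` likewise gives only a limit, < 100000 nM. Compound 2 `c1cncc(-c2ccccc2OCC2=NCCN2)c1` gives in this assay 2 nM, and this is the only actual number among the three results shown. The other two entries are limits, that of compound 3 at the limit of < 100000 nM in this assay, at which 1 of the 3 values shown sits, and that of compound 1 at the limit of < 5020 nM in this assay, at which 1 of the 3 values shown sits. Compound 4 `c1cnc(-c2ccccc2OCC2=NCCN2)nc1` is not yet measured in this assay. It differs from compound 2 in one place: pyrimidin-2-yl in place of pyridin-3-yl on an aromatic carbon, ortho to a group of 7 heavy atoms. Within the data shown here, no measured pair shows the size of such a change, so the expectation rests on compound 2 alone. A moderate loss is expected, in the direction of an effect only at larger amounts, as the step of a 13-fold higher number from compound 2 to compound 4 (1.10 log units; beyond the scatter) expresses. For compound 4 the estimate in this assay is 25 nM, with a range from 3 nM to 400 nM.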

Compound 4, half-maximal effective concentration: 1260 nM
The estimate for compound 4 lay 50-fold (1.70 log units) below the measured number; the measured number lies above the stated range.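

The series now has its first measured step at this place, on an aromatic carbon ortho to a group of 7 heavy atoms: in this assay, pyrimidin-2-yl in place of pyridin-3-yl gives a 630-fold higher number from compound 2 to compound 4 (2.80 log units; beyond the scatter). The read-out is thus highly sensitive to the identity of this ring, even though both groups are six-membered aromatic rings with the same heavy-atom count and the entering ring differs in carrying a second hetero atom. The results shown offer no measurement that accounts for the size of this step.

Going by these compounds, it remains open whether the step follows the second ring nitrogen or the placing of the ring nitrogens. Plain phenyl, unsubstituted pyridin-2-yl and pyrimidin-5-yl on the same aromatic carbon would help separate these two readings.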